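A Thiophene Ester Tested for Toxicity Toward Vero Cells

The compounds below may be only part of what the source reports. "The series", "measured", "known", "first", "only" and "open" are said of these compounds alone.

Compound 1 `CCCC(=O)OC1CCC(CN2CCN(c3cc(=O)c4cc(C(F)(F)F)cc([N+](=O)[O-])c4s3)CC2)CC1` and compound 2 `O=C(OC1CCC(CN2CCN(c3cc(=O)c4cc(C(F)(F)F)cc([N+](=O)[O-])c4s3)CC2)CC1)c1ccc(C(F)(F)F)cc1` share one core and differ only in the group attached to the ester carbonyl. In an ADME assay on Vero cells (Chlorocebus sabaeus) for cytotoxicity, read by MTT assay, with a stated time of 48 h (on this read-out higher numbers stand for weaker inhibition and lower numbers for stronger inhibition), compound 1 gives > 64 ug/mL, which is a limit of the assay rather than a number. In this assay compound 2 likewise gives > 64 ug/mL, again a limit. Because both values sit at the limit of > 64 ug/mL in this assay, at which 2 of the 2 values shown sit, the step that the two limits leave unreadable from compound 1 to compound 2 cannot be read in size. Compound 2 therefore stands at the limit of the measurement, with no number of its own. Compound 3 `O=C(OC1CCC(CN2CCN(c3cc(=O)c4cc(C(F)(F)F)cc([N+](=O)[O-])c4s3)CC2)CC1)c1cccs1` carries the change (thiophen-2-yl in place of 4-(trifluoromethyl)phenyl on a carbonyl carbon). Within the data shown here, no measured step offers a readable size to lean on, so the step that the limit leaves unreadable from compound 2 to compound 3 is expected to stay within the scatter, in no clear direction. Compound 3 is therefore estimated at 80 ug/mL, with a range from 40 ug/mL to 200 ug/mL, and the assay is expected most likely to report only a limit once more.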

Compound 3, half-maximal inhibitory concentration: > 64 ug/mL
Compound 3 was reported as a limit; the forecaster's own chance of this, stated with the estimate: 80%; the middle value does not contradict the limit.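

Compound 3 again gives only a limit, so none of the steps among compound 1, compound 2 and compound 3 can be read in size: the limit of > 64 ug/mL in this assay, at which 3 of the 3 values shown sit.

Still open is whether propyl, 4-(trifluoromethyl)phenyl and thiophen-2-yl on the carbonyl carbon differ at all in this assay, and at what concentration any of these compounds would reach half-maximal inhibition.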